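A few compounds are considered here, and "the series" means these few. Any claim that something is new, unique, unknown or untested is made for them only; others in the source may bear on it.

In a functional assay on MOLT-4 cells (Homo sapiens) for antiproliferative activity, read by CCK-8 assay, with a stated time of 72 h (a higher number here means a weaker inhibitor, a lower number a stronger inhibitor), compound 1 (`Cc1cc(Nc2cc(N3CCN(C)CC3)nc(Nc3ccc([N+](=O)[O-])cc3)n2)n[nH]1`) gives 18.1 nM while compound 2 (`Cc1cc(Nc2cc(N3CCN(C)CC3)nc(Nc3ccc(C#N)cc3)n2)n[nH]1`) gives 13.6 nM and so stands within the scatter of compound 1. Compound 3 (`COc1ccc(Nc2nc(Nc3cc(C)[nH]n3)cc(N3CCN(C)CC3)n2)cc1`) keeps the shared core and differs from compound 2 on an aromatic carbon of a six-membered aromatic ring of carbon only, para to a large group, with methoxy in place of cyano (methoxy in place of cyano on an aromatic carbon). For the measured compounds named here, the one measured step that bears on this is a 1.3-fold lower number from compound 1 to compound 2 (0.12 log units; within the scatter) for cyano in place of nitro, which lies within the scatter, and no measured compound carries methoxy. On that step alone, a small rise in the number or no change beyond the scatter is expected in this assay for compound 3. The estimated step is a 1.8-fold higher number from compound 2 to compound 3 (0.26 log units; within the scatter) on this reading. Compound 3 is expected at 25 nM with 8 nM to 80 nM as its estimated range.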

Compound 3, half-maximal inhibitory concentration: 116 nM
Estimate against measurement, compound 3: 4.6-fold (0.67 log units) below, and the stated range ends below it.
By their numbers in this assay, from the lowest: compounds 2 and 1 (each within the scatter of the next); then compound 3.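

In this assay, the place on the aromatic ring para to a large group turns out to be sensitive to what stands on it, with an 8.5-fold higher number from compound 2 to compound 3 (0.93 log units; beyond the scatter) for methoxy in place of cyano and a 6.4-fold higher number from compound 1 to compound 3 (0.81 log units; beyond the scatter) for methoxy in place of nitro. The earlier exchange of nitro for cyano stayed within the scatter, so that pair alone gave no sign that this position could move the number at all. The new compound shows that it can, and that the two groups which entered and left in the earlier step are not interchangeable with every group of similar size.

From the compounds shown here alone, it stays open whether a plain hydrogen, a chlorine atom, an amine or a carboxylic acid at this place would stand with cyano and nitro or with methoxy. No measurement shown here bears on why methoxy gives the higher number.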